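The source may hold more compounds than are shown below. What is called first, only, known or untested is meant among the compounds shown, and "the series" means these compounds.

Compound 1 `COC(=O)c1nc(C)n(-c2ccc(C(F)(F)F)cc2)n1` and compound 2 `COC(=O)c1nc(C)n(-c2ccc(F)cc2)n1` share one core and differ only by fluoro in place of trifluoromethyl on an aromatic carbon. In a functional assay on NPC-TW01 cells (Homo sapiens) for inhibition, read by MTT assay, with a stated time of 72 h (on this read-out higher numbers stand for weaker inhibition of growth and lower numbers for stronger inhibition of growth), compound 1 gives only a limit, > 100000 nM, which is the limit of > 100000 nM in this assay, at which 1 of the 3 values shown sits. Compound 2, in this assay, gives 15200 nM. The resulting step, an at least 6.5-fold lower number from compound 1 to compound 2 (0.81 log units; beyond the scatter), counts as at least modest. Compound 3 `CCOC(=O)c1nc(-c2ccc[nH]2)n(-c2ccc(C(F)(F)F)cc2)n1` rests on another core, and the difference between the two cores is not broken down here. In this assay compound 3 gives 76400 nM. Among the compounds with values here, compound 4 `CCOC(=O)c1nc(-c2ccc[nH]2)n(-c2ccc(F)cc2)n1` is obtained from compound 3 by fluoro in place of trifluoromethyl on an aromatic carbon, the same change at the same place as the one separating compound 1 from compound 2. The step from compound 3 to compound 4 is expected to be a 5.1-fold lower number from compound 3 to compound 4 (0.71 log units; beyond the scatter) in this assay, resting on the earlier step of an at least 6.5-fold lower number from compound 1 to compound 2 (0.81 log units; beyond the scatter). Compound 4 is accordingly estimated at 15000 nM, with a likely range from 5000 nM to 50000 nM.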

Compound 4, concentration for 50% growth inhibition: 64300 nM
Estimate against measurement, compound 4: 4.3-fold (0.63 log units) below; the whole stated range lies below it.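

In this assay, fluoro in place of trifluoromethyl gives a 1.2-fold lower number from compound 3 to compound 4 (0.07 log units; within the scatter), so the clear gain seen on the core of compound 1 does not carry over to the core of compound 3: the same change on two cores in this assay, an at least 6.5-fold lower number (0.81 log units; beyond the scatter) from compound 1 to compound 2 and a 1.2-fold lower number (0.07 log units; within the scatter) from compound 3 to compound 4, at least 5.5-fold (0.74 log units) apart, beyond the scatter of two such steps. Within the data shown here, the earlier step rests on a limit, the one given by compound 1: the limit of > 100000 nM in this assay, at which 1 of the 4 values shown sits. These two pairs show that the outcome of this change depends on the core, but they do not show which part of the core matters or how the change would behave on any other core.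

As far as these compounds go, the two cores differ in more than one place, so what separates the two results stays open. Also open, from the compounds shown here alone, is whether the pattern would hold with a carboxylic acid in place of the ester, or with an amine in place of fluoro.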